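Side-chain exchange from compound 2 to compound 3

This account rests on a few compounds, and the source may have more. Where it says the series, first, only, none or still open, it means among the compounds named here.

Among the measured compounds shown here, in a functional assay on HCT-116 cells (Homo sapiens) for cytotoxicity, read by MTT assay, with a stated time of 72 h (on this read-out lower numbers stand for stronger inhibition and higher numbers for weaker inhibition), compound 1 `COc1ncc(-c2ccc3nc(NC(=O)NCCN4CCCC4)nn3c2)cc1NS(=O)(=O)c1ccc(F)cc1` gives 230 nM and compound 2 `COc1ncc(-c2ccc3nc(NC(=O)NCCN(C)C)nn3c2)cc1NS(=O)(=O)c1ccc(F)cc1` gives 220 nM, so compound 2 stands level with the only other measured compound. Compound 3 `COc1ncc(-c2ccc3nc(NC(=O)NCC(=O)N4CCOCC4)nn3c2)cc1NS(=O)(=O)c1ccc(F)cc1` carries (morpholin-4-yl)carbonyl in place of (dimethylamino)methyl on a saturated chain carbon bound to an amide-type nitrogen. For the measured compounds named here, the sole measured step, a 1.0-fold lower number from compound 1 to compound 2 (0.02 log units; within the scatter), exchanges pyrrolidin-1-yl for dimethylamino and stays within the scatter. Going by the values given here, no measured compound carries (morpholin-4-yl)carbonyl, so that step is only a weak guide. In this assay the expected change is a 1.4-fold higher number from compound 2 to compound 3 (0.13 log units; within the scatter), not beyond the scatter. For compound 3 the estimate is 300 nM, with an expected range of 90 nM to 1000 nM.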

Compound 3, half-maximal inhibitory concentration: 490 nM
The estimate for compound 3 lay 1.6-fold (0.21 log units) below the measured number; the range from low to high includes it.
By their numbers in this assay, from the lowest: compounds 2 and 1 (each within the scatter of the next); then compound 3.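

In this assay, (morpholin-4-yl)carbonyl in place of (dimethylamino)methyl gives a 2.2-fold higher number from compound 2 to compound 3 (0.35 log units; beyond the scatter), and in place of (pyrrolidin-1-yl)methyl it gives a 2.1-fold higher number from compound 1 to compound 3 (0.33 log units; beyond the scatter). Among the compounds shown here, these are the first steps on this saturated chain carbon that lie beyond the scatter, so this position does respond to the change, though only modestly. Nothing measured here bears on the reason for the shift.

Going by these compounds, the exchange brings in the carbonyl and the morpholine ring together, so their separate shares remain open. A 2-(morpholin-4-yl)ethyl chain or a (dimethylamino)carbonyl group would separate them.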